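The source may hold more compounds than are shown below. What is called first, only, known or untested is meant among the compounds shown, and "the series" means these compounds.

Among the compounds with values here, in an ADME assay on a cell-free system (plasma, Homo sapiens) (on this read-out higher numbers stand for a larger free fraction and lower numbers for a smaller free fraction), compound 1 (`CCNC(=O)Nc1nc2cc(-c3cccnc3)c(=O)n(CC3CC3)c2s1`) gives 0.05 and compound 2 (`CCNC(=O)Nc1nc2cc(-c3cccnc3)c(=O)n(CC3CCOCC3)c2s1`) gives 0.14 as the higher of the only two numbers available. Compound 3 (`CCNC(=O)Nc1nc2cc(-c3cccnc3)c(=O)n(C(C)C(N)=O)c2s1`) keeps the shared core and differs from compound 2 on an aromatic nitrogen, with 1-carbamoylethyl in place of (oxan-4-yl)methyl on an aromatic nitrogen is the full count of that change. Within the data shown here, only one measured step bears on this group, namely a 2.8-fold higher number from compound 1 to compound 2 (0.45 log units; beyond the scatter) as a modest change. Neither measured compound carries a carbamoyl group, so that step is only a weak guide. A small upward move in this assay that stays within the scatter is therefore expected. The expected step is a 1.4-fold higher number from compound 2 to compound 3 (0.15 log units; within the scatter) as a tentative figure. For compound 3 the estimated value is 0.2 with an expected range from 0.1 to 0.38 in this measurement.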

Compound 3, unbound fraction: 0.25
Beside the measured number, compound 3's estimate is 1.3-fold (0.10 log units) below it; the range from low to high includes it.
By their numbers in this assay, from the lowest: compound 1; then compounds 2 and 3 (each within the scatter of the next).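

In this assay the aromatic nitrogen accepts a group with no ring: with 1-carbamoylethyl in place of (oxan-4-yl)methyl, the data show a 1.8-fold higher number from compound 2 to compound 3 (0.25 log units; within the scatter) and so do not separate the two groups. Against cyclopropylmethyl the same group gives a 5.0-fold higher number from compound 1 to compound 3 (0.70 log units; beyond the scatter) and thus a clear separation. Among these three compounds, then, the six-membered non-aromatic ring of compound 2 is not required to stand clear of compound 1, since compound 3 does so without any ring. Nothing available explains these differences in unbound fraction.

On these data alone, it remains open whether the result follows the carbamoyl group or the methyl branch of 1-carbamoylethyl. As far as these compounds go, what a carboxylic acid or an amine at the end of that chain would give also remains open.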